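This account rests on a few compounds, and the source may have more. Where it says the series, first, only, none or still open, it means among the compounds named here.

Measured compounds in an assay on HEK293 cells for antagonist activity at P2X purinoceptor 7 (Homo sapiens), read by fluorescence, with a stated time of 2 h; on this read-out higher numbers stand for weaker inhibition and lower numbers for stronger inhibition:
Compound 1, `O=C(c1ccc(Cl)c(C(F)(F)F)c1)N1CCC(n2cncc2-c2ccc(OS(=O)(=O)c3cccs3)cc2)CC1`, gives 238 nM.
Compound 2, `O=C(c1ccc(Cl)c(C(F)(F)F)c1)N1CCC(n2cncc2-c2ccc(OS(=O)(=O)c3cccc(Br)c3)cc2)CC1`, gives 896 nM.
Compound 3, `O=C(c1ccc(Cl)c(C(F)(F)F)c1)N1CCC(n2cncc2-c2ccc(OS(=O)(=O)c3cccc([N+](=O)[O-])c3)cc2)CC1`, gives 249 nM.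

Compound 3 stands second highest of these three numbers: it sits within the scatter of compound 1 (a 1.0-fold higher number from compound 1 to compound 3 (0.02 log units; within the scatter)), and only compound 2 lies clearly apart (a 3.6-fold lower number from compound 2 to compound 3 (0.56 log units; beyond the scatter)). Compound 4, `O=C(c1ccc(Cl)c(C(F)(F)F)c1)N1CCC(n2cncc2-c2ccc(OS(=O)(=O)c3cccc4cnccc34)cc2)CC1`, has not been measured. It differs from compound 3 in one place: isoquinolin-5-yl in place of 3-nitrophenyl on a sulfonyl sulfur. Among the compounds with values here, the steps that bear on this change all exchange the group on the sulfonyl sulfur: a 3.8-fold higher number from compound 1 to compound 2 (0.58 log units; beyond the scatter), a 1.0-fold higher number from compound 1 to compound 3 (0.02 log units; within the scatter) and a 3.6-fold lower number from compound 2 to compound 3 (0.56 log units; beyond the scatter). Two of the three groups tried gave nearly the same number and one gave a modestly higher one, so a step of modest size in either direction, or none beyond the scatter, is expected in this assay. Compound 4 is therefore estimated at 350 nM, within a range from 120 nM to 1100 nM, which means an expected step of a 1.4-fold higher number from compound 3 to compound 4 (0.15 log units; within the scatter).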

Compound 4, half-maximal inhibitory concentration: 45 nM
Beside the measured number, compound 4's estimate is 7.8-fold (0.89 log units) above it, and the stated range ends above it.
By their numbers in this assay, from the lowest: compound 4; then compounds 1 and 3 (each within the scatter of the next); then compound 2.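

In this assay, the group on the sulfonyl sulfur proves able to shift the number further than the earlier exchanges showed: isoquinolin-5-yl gives a lower number than 3-nitrophenyl (a 5.5-fold lower number from compound 3 to compound 4 (0.74 log units; beyond the scatter)), thiophen-2-yl (a 5.3-fold lower number from compound 1 to compound 4 (0.72 log units; beyond the scatter)) and 3-bromophenyl (a 20-fold lower number from compound 2 to compound 4 (1.30 log units; beyond the scatter)). Among the groups shown, only isoquinolin-5-yl has two rings, and it also brings a ring nitrogen. Nothing shown gives a reason for this gain.

As far as these compounds go, whether the second ring or the ring nitrogen matters stays open. Naphthalen-1-yl on the same sulfonyl sulfur, with carbon only in both rings, would separate the two.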